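Trifluoromethyl for ethoxy on a carbonyl carbon

The source may hold more compounds than are shown below. What is called first, only, known or untested is meant among the compounds shown, and "the series" means these compounds.

Of the compounds shown here, three sharing one core have been measured in a physicochemical assay for solubility, in phosphate buffer, with a stated time of 18 h, at pH 7.4; a lower number here means a less soluble compound, a higher number a more soluble compound. Compound 1 `COc1cc2ncnc(-n3nc(-c4ccccn4)nc3N)c2cc1[N+](=O)[O-]` gives 2000 nM, compound 2 `COc1cc2ncnc(-n3nc(-c4ccccn4)nc3N)c2cc1OCc1ccccc1` gives 58000 nM, and compound 3 `CCOC(=O)NCCCOc1cc2c(-n3nc(-c4ccccn4)nc3N)ncnc2cc1OC` gives 16000 nM. That makes compound 3 the second highest of the three numbers, with clear gaps on both sides.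

The next compound, compound 4 `COc1cc2ncnc(-n3nc(-c4ccccn4)nc3N)c2cc1OCCCNC(=O)C(F)(F)F`, differs from compound 3 in a single group: trifluoromethyl in place of ethoxy on a carbonyl carbon. In short, trifluoromethyl stands in place of ethoxy on a carbonyl carbon, and that carbon's other neighbour is an amide-type nitrogen.

The measured steps bear on this change only indirectly. Putting benzyloxy in place of nitro gave a large step, a 29-fold higher number from compound 1 to compound 2 (1.46 log units; beyond the scatter). Putting 3-((ethoxycarbonyl)amino)propoxy in place of nitro gave a modest one, an 8.0-fold higher number from compound 1 to compound 3 (0.90 log units; beyond the scatter). Exchanging phenyl for 2-((ethoxycarbonyl)amino)ethyl gave another modest step, a 3.6-fold lower number from compound 2 to compound 3 (0.56 log units; beyond the scatter). Among the measured compounds shown here, all three swap much larger pieces than this one, and none alters the group on the carbonyl carbon, so no measured step shows the direction of this change.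

No step beyond the scatter is therefore expected, and the expected step is a 1.3-fold lower number from compound 3 to compound 4 (0.12 log units; within the scatter). The estimate for compound 4 is 12000 nM, within an expected range of 4000 nM to 40000 nM.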

Compound 4, solubility: 1000 nM
Estimate against measurement, compound 4: 12-fold (1.08 log units) above; measured number below the stated range.
By their numbers in this assay, from the lowest: compounds 4 and 1 (each within the scatter of the next); then compound 3; then compound 2.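

In this assay, the group on this carbonyl carbon turns out to matter a great deal: trifluoromethyl in place of ethoxy gives a 16-fold lower number from compound 3 to compound 4 (1.20 log units; beyond the scatter) as a large step from one small exchange at the far end of the side chain. The earlier compounds shown here showed this side chain, with ethoxy on the carbonyl carbon, giving a higher number than nitro, but that gain does not survive the exchange: with trifluoromethyl there, the comparison gives a 2.0-fold lower number from compound 1 to compound 4 (0.30 log units; within the scatter) and leaves compound 4 and compound 1 impossible to tell apart. Against the benzyloxy group the gap also widens, to a 58-fold lower number from compound 2 to compound 4 (1.76 log units; beyond the scatter) in place of the more modest gap seen with the ethoxy version of the chain.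

Still open, going by these compounds, is where other groups would fall, such as methyl on the same carbonyl carbon, a free amine at the end of the chain, or a longer chain carrying the same trifluoromethyl amide. Nothing among the data shown explains why this exchange moves the number so far.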